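This account rests on a few compounds, and the source may have more. Where it says the series, first, only, none or still open, it means among the compounds named here.

Working notes on the series. Measured so far: compound 1 `CC1CCC(/C=N/c2ccccc2O)=C2NC=C(C(=O)O)C(=O)N21`, compound 2 `CC1CCC(/C=N/c2ccc(O)cc2)=C2NC=C(C(=O)O)C(=O)N21` and compound 3 `CCOc1ccc(/N=C/C2=C3NC=C(C(=O)O)C(=O)N3C(C)CC2)cc1`. In a functional assay on the whole organism with Rattus norvegicus as the target (on this read-out higher numbers stand for an effect only at larger amounts of compound and lower numbers for an effect already at smaller amounts), compound 1 gives 4.11 umol/kg, compound 2 gives 1.2 umol/kg and compound 3 gives 8.96 umol/kg, so compound 3 stands highest of the three numbers. The steps seen: a 3.4-fold lower number from compound 1 to compound 2 (0.53 log units; beyond the scatter); a 7.5-fold higher number from compound 2 to compound 3 (0.87 log units; beyond the scatter). Compound 4 `Cc1ccc(/N=C/C2=C3NC=C(C(=O)O)C(=O)N3C(C)CC2)cc1` differs from compound 3 by methyl in place of ethoxy on an aromatic carbon. Within the data shown here, the only step touching this position is a 7.5-fold higher number from compound 2 to compound 3 (0.87 log units; beyond the scatter), which put ethyl in place of hydrogen on the oxygen; no measured step removes the ethoxy itself, so the direction is open. A step no larger than modest is expected, a 1.5-fold lower number from compound 3 to compound 4 (0.17 log units; within the scatter). Compound 4 is estimated at 6 umol/kg, range 2 umol/kg to 18 umol/kg.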

Compound 4, dose for 50% inhibition: 3.6 umol/kg
Beside the measured number, compound 4's estimate is 1.7-fold (0.22 log units) above it, and the stated range covers the measured number.
By their numbers in this assay, from the lowest: compound 2; then compounds 4 and 1 (each within the scatter of the next); then compound 3.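

In this assay, the aromatic carbon para to a large group now carries three groups whose numbers are separated beyond the scatter: ethoxy gives way to methyl with a 2.5-fold lower number from compound 3 to compound 4 (0.40 log units; beyond the scatter) on this read-out, and hydroxy gives way to methyl with a 3.0-fold higher number from compound 2 to compound 4 (0.48 log units; beyond the scatter) on the same carbon. The order from the lowest number is therefore hydroxy, methyl, ethoxy. Compared with the 2-hydroxyphenyl group, 4-methylphenyl shows a 1.1-fold lower number from compound 1 to compound 4 (0.06 log units; within the scatter) and cannot be told apart from it. No measurement at hand accounts for these steps. Going by these compounds, how an amine or a longer chain on this carbon would fall against hydroxy, methyl and ethoxy remains open.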